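The source may report more compounds than this note shows. Statements on the series, on what has been measured and on what is new or still open speak of the compounds shown alone.

Measured so far in a functional assay on A375P cells (Homo sapiens) for antiproliferative activity, read by MTT assay, with a stated time of 48 h; a higher number here means a weaker inhibitor, a lower number a stronger inhibitor: compound 1 `Cc1cc(C(=O)Nc2cccc(-c3ccnc4c(N)cccc34)c2)ccc1Br` gives 9900 nM; compound 2 `Nc1cccc2c(-c3cccc(NC(=O)c4ccc5c(c4)OCCO5)c3)ccnc12` gives 860 nM.

Compound 2 holds the lowest of the two numbers in this assay; the nearest is compound 1, beyond the scatter. Compound 3 `Cc1cc(C(=O)Nc2cccc(-c3ccnc4c(N)cccc34)c2)c(C)o1` differs from compound 2 by 2,5-dimethylfuran-3-yl in place of 2,3-dihydro-1,4-benzodioxin-6-yl on a carbonyl carbon. Within the data shown here, the only step that bears on this position is a 12-fold lower number from compound 1 to compound 2 (1.06 log units; beyond the scatter), a large step at the same carbonyl carbon. Among the measured compounds shown here, with 2,5-dimethylfuran-3-yl untested and no second step to fix a direction, the expectation for compound 3 is a moderate rise over compound 2, a 3.5-fold higher number from compound 2 to compound 3 (0.54 log units; beyond the scatter). The estimate for compound 3 in this assay is 3000 nM, ranging from 700 nM to 12000 nM.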

Compound 3, half-maximal inhibitory concentration: > 20000 nM
Compound 3: no number, only a limit; the forecaster's own chance of this, stated with the estimate: 5%; at least 6.6-fold (0.82 log units) between middle value and limit.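

In this assay the result for compound 3 is a limit, not a number: the limit of > 20000 nM in this assay, at which 1 of the 3 values shown sits.

On the carbonyl carbon, the change to 2,5-dimethylfuran-3-yl gives a second large step, an at least 23-fold higher number from compound 2 to compound 3 (1.36 log units; beyond the scatter), so the low number of compound 2 does not carry over to this replacement. Against 4-bromo-3-methylphenyl, the same group gives an at least 2.0-fold higher number from compound 1 to compound 3 (0.30 log units; that floor lies within the scatter), and that floor alone sets no firm order between the two groups.

Still open, from the compounds shown here alone, is whether a plain phenyl or a 4-methoxyphenyl on this carbonyl carbon would stay near compound 2. The compounds shown also do not separate the contribution of the non-aromatic ring of 2,3-dihydro-1,4-benzodioxin-6-yl from that of its aromatic ring.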